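The source may report more compounds than this note shows. Statements on the series, on what has been measured and on what is new or still open speak of the compounds shown alone.

Working notes on the series.

The shared core carries an allyl group and a 2-methoxyphenyl group; the second exocyclic arylidene is varied. Compound 1 `C=CCn1c(=O)/c(=C\c2ccccc2Cl)[nH]c(=O)/c1=C\c1ccccc1OC` bears a 2-chlorophenyl group at that position and in a functional assay on HL-60 cells (Homo sapiens) for cytotoxicity, read by CCK-8 assay, with a stated time of 72 h (a lower number here means a stronger inhibitor, a higher number a weaker inhibitor), compound 1 gives 4200 nM. Compound 2 `C=CCn1c(=O)/c(=C\c2ccc(Cl)c(Cl)c2)[nH]c(=O)/c1=C\c1ccccc1OC` carries a 3,4-dichlorophenyl group, and in this assay compound 2 is reported as "not active" (no number reported), without a number. Within the data shown here, compound 3 `C=CCn1c(=O)/c(=C\c2cc(Br)ccc2F)[nH]c(=O)/c1=C\c1ccccc1OC` has a 5-bromo-2-fluorophenyl group; in this assay compound 3 gives 17400 nM, the highest of the two numbers reported, with a 4.1-fold higher number from compound 1 to compound 3 (0.62 log units; beyond the scatter) as the only single-point step on record.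

Compound 4 `C=CCn1c(=O)/c(=C\c2ccc(F)c(Br)c2)[nH]c(=O)/c1=C\c1ccccc1OC` differs from compound 3 in that (3-bromo-4-fluorophenyl in place of 5-bromo-2-fluorophenyl on a double-bonded chain carbon bound to an aromatic carbon). Among the measured compounds shown here, no measured step bears directly on moving the halogens around the ring; the one measured step, from compound 1 to compound 3, concerns a different exchange of the whole aryl group and is modest. What compound 2 shows is that its 3,4-disubstituted aryl gave no measurable number, and compound 4 carries the same substitution pattern with different halogens. Compound 4 is therefore expected to sit near the number of compound 3, with the step of a 1.6-fold higher number from compound 3 to compound 4 (0.21 log units; within the scatter) being my estimate, and I would not be surprised if its number ended up outside what the assay can resolve. For compound 4 the estimate in this assay is 28000 nM, with a range from 9000 nM to 90000 nM.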

Compound 4, half-maximal inhibitory concentration: "not active" (no number reported)
For compound 4 the study gives words and no number, so the estimate cannot be set against anything.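

In this assay, among these compounds, compound 4 is reported as "not active" (no number reported), so no step from compound 3 to compound 4 can be read. No supporting measurement bears on this result. The compounds shown leave open how far compound 2 and compound 4, both without a number, actually lie from compound 3.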